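From a hydroxy-methoxy aryl to a methylsulfanyl aryl

The source may report more compounds than this note shows. Statements on the series, on what has been measured and on what is new or still open speak of the compounds shown alone.

In a functional assay on HL-60 cells (Homo sapiens) for inhibition, read by resazurin assay, with a stated time of 72 h (a lower number here means a stronger inhibitor, a higher number a weaker inhibitor), compound 2 (`COc1ccc(C2C(O)C(=O)N2c2cc(OC)c(OC)c(OC)c2)cc1O`) stands lowest of three at 5 nM against compound 1 (`CCSc1ccc(C2C(O)C(=O)N2c2cc(OC)c(OC)c(OC)c2)cc1`) at 16 nM and compound 3 (`C=CC1C(=O)N(c2cc(OC)c(OC)c(OC)c2)C1c1ccc(OC)cc1`) at 33 nM in this small set. Compound 4 (`COc1cc(N2C(=O)C(O)C2c2ccc(SC)cc2)cc(OC)c1OC`) differs from compound 2 by 4-(methylsulfanyl)phenyl in place of 3-hydroxy-4-methoxyphenyl on a saturated ring carbon on a saturated ring carbon of a four-membered non-aromatic ring with 1 nitrogen. Within the data shown here, the one measured step bearing on this is a 3.2-fold lower number from compound 1 to compound 2 (0.51 log units; beyond the scatter) and it is modest but beyond the scatter, with 3-hydroxy-4-methoxyphenyl replacing 4-(ethylsulfanyl)phenyl. Read backwards, it points to a higher number of similar size in this assay for the change to 4-(methylsulfanyl)phenyl. Thus a 3.0-fold higher number from compound 2 to compound 4 (0.48 log units; beyond the scatter) is the expected step here. The estimated value for compound 4 is 15 nM with an expected range from 6 nM to 40 nM in this measurement.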

Compound 4, half-maximal inhibitory concentration: 15 nM
Beside the measured number, compound 4's estimate shows no gap at the digits printed, and the stated range covers the measured number.
By their numbers in this assay, from the lowest: compound 2; then compounds 4 and 1 (each within the scatter of the next); then compound 3.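

In this assay the step on the sulfur chain is a 1.1-fold lower number from compound 1 to compound 4 (0.03 log units; within the scatter) and so the two sulfur-bearing aryl groups cannot be told apart at this saturated ring carbon. The step of a 3.0-fold higher number from compound 2 to compound 4 (0.48 log units; beyond the scatter) stands beside the earlier one from the ethylsulfanyl compound, so the gap to 3-hydroxy-4-methoxyphenyl now holds for both sulfur-bearing groups. Still open, as far as these compounds go, is whether the hydroxy group alone carries that gap, and how an amine in its place or a longer chain on the sulfur would stand. No measured evidence explains the gap.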